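Aryl sulfonamides on the shared core: compound 1 to compound 3

The source may report more compounds than this note shows. Statements on the series, on what has been measured and on what is new or still open speak of the compounds shown alone.

Measured so far:
- compound 1 `Cc1cccc(NS(=O)(=O)c2ccc(N3CCNC3=O)cc2)c1` — 190 nM
- compound 2 `Cc1ccc(NS(=O)(=O)c2ccc(N3CCNC3=O)cc2)cc1C` — 230 nM

In a functional assay on MCF7 cells (Homo sapiens) for antiproliferative activity, read by sulforhodamine B assay, with a stated time of 48 h (a higher number here means a weaker inhibitor, a lower number a stronger inhibitor), compound 1 gives 190 nM, the lowest of the two numbers recorded, though its nearest neighbour compound 2 sits within the scatter of it. Going by the values given here, the one measured step, a 1.2-fold higher number from compound 1 to compound 2 (0.08 log units; within the scatter), shows that adding a methyl on an aromatic carbon of the aryl on the sulfonamide nitrogen leaves the read-out essentially unchanged.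

Compound 3 `O=C1NCCN1c1ccc(S(=O)(=O)Nc2ccc(Cl)cc2)cc1` is not yet measured. Relative to compound 1 the change is 4-chlorophenyl in place of 3-methylphenyl on a sulfonamide nitrogen. Among the compounds with values here, no measured step exchanges one aryl for another, so the step from compound 1 to compound 2 bears on it only in showing that this aryl tolerates substitution without a shift beyond the scatter. The step expected in this assay is therefore small, a 1.1-fold higher number from compound 1 to compound 3 (0.04 log units; within the scatter), with no clear direction. For compound 3 the estimated value is 210 nM, in the range 90 nM to 500 nM.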

Compound 3, half-maximal inhibitory concentration: 170 nM
For compound 3 the middle estimate is 1.2-fold (0.09 log units) above the measured one; the measured number falls inside the stated range.
By their numbers in this assay, from the lowest: compounds 3, 1 and 2 (each within the scatter of the next).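

In this assay the aryl on a sulfonamide nitrogen can be exchanged outright and not only given an extra methyl: 4-chlorophenyl in place of 3-methylphenyl gives (a 1.1-fold lower number from compound 1 to compound 3 (0.05 log units; within the scatter)), and 4-chlorophenyl in place of 3,4-dimethylphenyl gives (a 1.4-fold lower number from compound 2 to compound 3 (0.13 log units; within the scatter)). A chlorine on this ring therefore reads the same as the methyl-bearing aryls, and all three substitution patterns at this position lie within the scatter of one another. No supporting data accompany these results.

As far as these compounds go, all three aryls are phenyl rings carrying only methyl or chlorine, so it remains open whether this position also accepts an amine or a carboxylic acid on the ring, or a longer chain in place of the aryl. The shared core is the same in all three compounds, so these values say nothing about changes to it.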